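The source may hold more compounds than are shown below. What is called first, only, known or untested is meant among the compounds shown, and "the series" means these compounds.

In a functional assay on SK-N-SH cells (Homo sapiens) for inhibition, read by MTT assay (on this read-out higher numbers stand for weaker inhibition and lower numbers for stronger inhibition), the three measured compounds are:

Compound 1 `CCCCCCCCCCn1cc(/C=C/C(=O)c2ccc(NC(=O)CN3CCN(c4ccccc4)CC3)cc2)nn1` gives 39500 nM.
Compound 2 `O=C(CN1CCN(c2ccccc2)CC1)Nc1ccc(C(=O)/C=C/c2cn(Cc3ccc(Br)cc3)nn2)cc1` gives 72400 nM.
Compound 3 `CCCCCCCCCCn1cc(/C=C/C(=O)c2ccc(NC(=O)CBr)cc2)nn1` gives 8680 nM.

Compound 3 gives the lowest number of the three, and so the strongest inhibition: the step from compound 1 to compound 3 is a 4.6-fold lower number from compound 1 to compound 3 (0.66 log units; beyond the scatter), and the gap to compound 2 is wider still, so both separations lie beyond the scatter.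

Compound 4 `O=C(CBr)Nc1ccc(C(=O)/C=C/c2cn(Cc3ccc(Br)cc3)nn2)cc1` is the unmeasured one. It differs from compound 3 by 4-bromophenyl in place of nonyl on a saturated chain carbon bound to an aromatic nitrogen.

Going by the values given here, one measured step bears directly on this change. It is the same swap, made on compound 1 to give compound 2: a 1.8-fold higher number from compound 1 to compound 2 (0.26 log units; within the scatter). That step stayed within the scatter, so the swap did not change inhibition in any clear direction there. Applied to compound 3, the expectation is a step of about the same kind, a 1.6-fold higher number from compound 3 to compound 4 (0.21 log units; within the scatter), leaning to a somewhat higher number but not clearly beyond the scatter. Compound 4 is therefore estimated at 14000 nM, with a range from 5000 nM to 40000 nM.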

Compound 4, half-maximal inhibitory concentration: 8300 nM
Beside the measured number, compound 4's estimate is 1.7-fold (0.23 log units) above it, within the range that was stated.
By their numbers in this assay, from the lowest: compounds 4 and 3 (each within the scatter of the next); then compounds 1 and 2 (each within the scatter of the next).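

In this assay, going by these compounds alone, the swap of nonyl for 4-bromophenyl now reads on a second core as a 1.0-fold lower number from compound 3 to compound 4 (0.02 log units; within the scatter), so on neither core does it clearly change inhibition, and the two readings agree: the same change on two cores in this assay, a 1.8-fold higher number (0.26 log units; within the scatter) from compound 1 to compound 2 and a 1.0-fold lower number (0.02 log units; within the scatter) from compound 3 to compound 4, 1.9-fold (0.28 log units) apart, within the scatter of two such steps The change from 4-phenylpiperazin-1-yl to bromo, first seen on one core, now gives an 8.7-fold lower number from compound 2 to compound 4 (0.94 log units; beyond the scatter), and again the two readings agree: the same change on two cores in this assay, a 4.6-fold lower number (0.66 log units; beyond the scatter) from compound 1 to compound 3 and an 8.7-fold lower number (0.94 log units; beyond the scatter) from compound 2 to compound 4, 1.9-fold (0.28 log units) apart, within the scatter of two such steps Across these four compounds, the number follows the group on the saturated chain carbon bound to a carbonyl carbon and not the group on the chain carbon bound to an aromatic nitrogen, and no compound goes against this.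

On these data alone, whether bromo itself matters, or only the loss of 4-phenylpiperazin-1-yl, stays open, and chloro or a morpholine in its place would help to separate the two. As far as these compounds go, it is also open whether a short ethyl chain or a chain ending in a carboxylic acid would leave the number as unchanged as 4-bromophenyl does.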